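The compounds below may be only part of what the source reports. "The series", "measured", "known", "first", "only" and "open" are said of these compounds alone.

Working notes on the series.

Compound 2 `CCOC(=O)c1cnn(C)c1NC(=O)NCc1ccccc1` gives 18 nM in a functional assay on cells (Neutrophil, Homo sapiens) for inhibition, with a stated time of 10 min; a higher number here means a weaker inhibitor, a lower number a stronger inhibitor. Among the three measured compounds it stands second highest; its nearest neighbour is compound 1 `CCCC(O)Cn1ncc(C(=O)OCC)c1NC(=O)NC(C)C`, which in this assay gives 20 nM, a gap within the scatter, and the furthest is compound 3 `CCCC(O)Cn1ncc(C(=O)OCC)c1NC(=O)NCc1ccccc1`, which gives 0.43 nM.

Compound 4 `CCOC(=O)c1cnn(C)c1NC(=O)NC(C)C` is not yet measured. It differs from compound 2 by isopropyl in place of benzyl on an amide-type nitrogen. Among the compounds with values here, the one measured step that bears directly on this exchange is the reverse one, a 47-fold lower number from compound 1 to compound 3 (1.67 log units; beyond the scatter), run on the core carrying the 1-hydroxybutyl chain. The other step, a 42-fold lower number from compound 2 to compound 3 (1.62 log units; beyond the scatter), concerns the chain rather than the amide substituent, but it shows that compound 2 and compound 1 sit close together, so the amide-side change appears to act on its own.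

Reading the benzyl-to-isopropyl exchange as the reverse of the step seen from compound 1 to compound 3, a large rise in the number is expected for compound 4, of about a 47-fold higher number from compound 2 to compound 4 (1.67 log units; beyond the scatter), so that compound 4 is estimated at 850 nM in this assay, with a range of 300 nM to 2500 nM.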

Compound 4, half-maximal inhibitory concentration: 77 nM
Compound 4: the middle estimate sits 11-fold (1.04 log units) above what was measured; measured number outside the range, below it.
By their numbers in this assay, from the lowest: compound 3; then compounds 2 and 1 (each within the scatter of the next); then compound 4.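

The exchange of benzyl for isopropyl on the amide-type nitrogen is much smaller on the core of compound 2 than on the core carrying the 1-hydroxybutyl chain, with a 4.3-fold higher number from compound 2 to compound 4 (0.63 log units; beyond the scatter) in this assay: the same change on two cores in this assay, a 47-fold lower number (1.67 log units; beyond the scatter) from compound 1 to compound 3 and a 4.3-fold lower number (0.63 log units; beyond the scatter) from compound 4 to compound 2, 11-fold (1.04 log units) apart, beyond the scatter of two such steps

Removing the 1-hydroxybutyl chain likewise has a much smaller effect when isopropyl rather than benzyl sits on that nitrogen, with a 3.9-fold higher number from compound 1 to compound 4 (0.59 log units; beyond the scatter): the same change on two cores in this assay, a 42-fold lower number (1.62 log units; beyond the scatter) from compound 2 to compound 3 and a 3.9-fold lower number (0.59 log units; beyond the scatter) from compound 4 to compound 1, 11-fold (1.04 log units) apart, beyond the scatter of two such steps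

The two changes are thus not independent in these four compounds, as benzyl and the 1-hydroxybutyl chain together give more than their separate steps add up to.

As far as these compounds go, whether this coupling extends to other groups on the amide-type nitrogen, such as cyclohexyl or phenethyl, remains open. Also open, from the compounds shown here alone, is whether a plain butyl chain in place of the 1-hydroxybutyl chain would keep it.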